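The source may hold more compounds than are shown below. What is called first, only, known or untested is meant among the compounds shown, and "the series" means these compounds.

Compound 1 `Nc1cc(N2CCN(c3cccc(Cl)c3)CC2)ncn1` carries an amino group on its core. In an assay for inhibition of ribosomal protein S6 kinase beta-1 variant D18H,T412E (Homo sapiens), read by a luciferase reporter and chemiluminescence, with a stated time of 3 h (on this read-out lower numbers stand for stronger inhibition and higher numbers for weaker inhibition), compound 1 gives > 2000 nM, which is a limit of the assay and not a number. Compound 2 `Cc1c(N)ncnc1N1CCN(c2cccc(Cl)c2)CC1` differs by methyl in place of hydrogen on an aromatic carbon. In this assay compound 2 gives > 2000 nM, again a limit rather than a number. The step that the two limits leave unreadable from compound 1 to compound 2 cannot be read because both values sit at the limit of > 2000 nM in this assay, at which 2 of the 3 values shown sit. Compound 3 `Cc1ccc(Cl)cc1N1CCN(c2ncnc3[nH]ncc23)CC1` rests on a different core; how the two cores differ is not broken down here. In this assay, going by the values given here, compound 3 gives 13 nM, the only number among the three. Compound 4 `Cc1nc(N2CCN(c3cc(Cl)ccc3C)CC2)c2cn[nH]c2n1` is not yet measured and differs from compound 3 by methyl in place of hydrogen on an aromatic carbon, the same kind of change as that from compound 1 to compound 2, though the methyl now enters between two ring nitrogen atoms, meta to a fused ring and para to a fused ring, not ortho to an amino group. The expected step of a 1.5-fold higher number from compound 3 to compound 4 (0.19 log units; within the scatter) is small, since the entering group is one carbon and a step that the two limits leave unreadable from compound 1 to compound 2 gives no readable size to lean on. Compound 4 is therefore estimated at 20 nM, between 6 nM and 70 nM.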

Compound 4, half-maximal inhibitory concentration: > 2000 nM
Compound 4: no number, only a limit; the forecaster's own chance of this, stated with the estimate: 5%; at least 100-fold (2.00 log units) between middle value and limit.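

On the core of compound 3, methyl in place of hydrogen on an aromatic carbon, between two ring nitrogen atoms, gives an at least 150-fold higher number from compound 3 to compound 4 (2.18 log units; beyond the scatter) in this assay. In this assay compound 4 gives > 2000 nM, a limit of the assay and not a number. The same kind of change on the core of compound 1 cannot be read, so this single large step does not show whether the result carries from one core to another: the limit of > 2000 nM in this assay, at which 3 of the 4 values shown sit.

From the compounds shown here alone, it remains open whether a group other than methyl, such as ethyl or hydroxyl, would be tolerated at this place on the core of compound 3. Going by these compounds, it also remains open how this methyl would behave on a core where the starting compound gives a number.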